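The source may report more compounds than this note shows. Statements on the series, on what has been measured and on what is new or still open speak of the compounds shown alone.

Of the compounds shown here, three built on one shared core have been tested in a functional assay on Jurkat cells for inhibition of nuclear factor NF-kappa-B complex (Homo sapiens); a higher number here means a weaker inhibitor, a lower number a stronger inhibitor. Compound 1 `CCOC(=O)c1cnc(CC)nc1NN1C(=O)C=C(C)C1=O` gives 10000 nM. Compound 2 `CCOC(=O)c1cnc(C(C)(C)C)nc1NN1C(=O)C=C(C)C1=O` gives 1000 nM. Compound 3 `CCOC(=O)c1cnc(-c2cnc3ccccc3c2)nc1NN1C(=O)C=C(C)C1=O` gives 6000 nM. Among these three numbers compound 3 stands second highest; the smaller gap to a neighbour is a 1.7-fold lower number from compound 1 to compound 3 (0.22 log units; within the scatter), and the larger gap is a 6.0-fold higher number from compound 2 to compound 3 (0.78 log units; beyond the scatter). Among the measured compounds shown here, the only other step so far is a 10-fold lower number from compound 1 to compound 2 (1.00 log units; beyond the scatter), which is beyond the scatter.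

Compound 4 `CCOC(=O)c1cnc(-c2ccc(C)s2)nc1NN1C(=O)C=C(C)C1=O` differs from compound 3 in a single place: 5-methylthiophen-2-yl in place of quinolin-3-yl on an aromatic carbon. For the measured compounds named here, no measured step exchanges one aromatic ring for another at this position, so the available evidence bears only indirectly. The two steps that bring quinolin-3-yl in, a 1.7-fold lower number from compound 1 to compound 3 (0.22 log units; within the scatter) and a 6.0-fold higher number from compound 2 to compound 3 (0.78 log units; beyond the scatter), show that an aromatic group there lands close to the ethyl compound and above the tert-butyl compound. Another aromatic group, smaller and carrying a sulfur, is therefore expected to leave the number roughly where compound 3 sits, with a 1.5-fold lower number from compound 3 to compound 4 (0.18 log units; within the scatter) expected to stay within the scatter. Compound 4 is estimated to give 4000 nM in this assay, with an expected range from 1500 nM to 12000 nM.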

Compound 4, half-maximal inhibitory concentration: 200 nM
Compound 4: middle estimate off by 20-fold (1.30 log units), on the high side; the measured number lies below the stated range.
By their numbers in this assay, from the lowest: compound 4; then compound 2; then compounds 3 and 1 (each within the scatter of the next).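

In this assay, among the compounds shown here, the earlier compounds left an aromatic group at this position looking no better than tert-butyl, but compound 4 changes that picture: 5-methylthiophen-2-yl in place of quinolin-3-yl gives a 30-fold lower number from compound 3 to compound 4 (1.48 log units; beyond the scatter), so which aromatic ring sits here matters a great deal, not merely whether one is present. The same group also outdoes both alkyl groups, with a 5.0-fold lower number from compound 2 to compound 4 (0.70 log units; beyond the scatter) and a 50-fold lower number from compound 1 to compound 4 (1.70 log units; beyond the scatter), which makes compound 4 the strongest inhibitor of the four and shows that this position can carry a group that beats tert-butyl. Nothing available explains why this single five-membered ring does so much better than the two-ring quinolin-3-yl group.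

This change alters the ring size, the hetero atom and the presence of a methyl group all at once, so the compounds shown cannot say which of these differences accounts for the step. A plain thiophen-2-yl group, a phenyl ring and a 5-chlorothiophen-2-yl group would be natural comparisons for pulling these differences apart.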